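A few compounds are considered here, and "the series" means these few. Any claim that something is new, unique, unknown or untested is made for them only; others in the source may bear on it.

Compound 1 `C=CCOC(=O)Nc1ccc([Se]C#N)cc1`: 9800 nM
Compound 2 `CCCCOC(=O)Nc1ccc([Se][Se]c2ccc(NC(=O)OCCCC)cc2)cc1`: 26000 nM
Compound 3 `C=CCOC(=O)Nc1ccc([Se][Se]c2ccc(NC(=O)OCC=C)cc2)cc1`: 21500 nM

In an ADME assay on 184B5 cells (Homo sapiens) for cytotoxicity, read by MTT assay, with a stated time of 72 h (a lower number here means a stronger inhibitor of growth, a higher number a weaker inhibitor of growth), compound 1 gives the lowest of these three numbers. Compound 3 and compound 2 both give higher numbers, and each of those gaps lies beyond the usual scatter of repeated measurements.

Compound 4 `CCCCCCOC(=O)Nc1ccc([Se]C#N)cc1` keeps the core of compound 1 and differs from it in one place: pentyl in place of vinyl on a saturated chain carbon bound to an oxygen next to a carbonyl group. For the measured compounds named here, no pair of measured compounds shows the effect of this particular change, so there is no measured step to lean on. The change touches only the chain on the carbamate and leaves the rest untouched, so only a small step is expected. The step of a 1.4-fold lower number from compound 1 to compound 4 (0.15 log units; within the scatter) is expected to be small, toward a slightly lower number, within the scatter. Compound 4 is therefore estimated at 7000 nM, with a range from 2500 nM to 20000 nM.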

Compound 4, concentration for total growth inhibition: 20000 nM
For compound 4 the middle estimate is 2.9-fold (0.46 log units) below the measured one; measured number inside the range.
By their numbers in this assay, from the lowest: compound 1; then compounds 4, 3 and 2 (each within the scatter of the next).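

In this assay, pentyl in place of vinyl on a saturated chain carbon bound to an oxygen next to a carbonyl group gives a 2.0-fold higher number from compound 1 to compound 4 (0.31 log units; beyond the scatter) and a weaker inhibitor of growth, so this position does respond to the chain it carries. This is the only comparison shown that differs in one place. Nothing measured here explains the shift.

The swap changes chain length and removes a double bond together, and the two effects cannot be separated. From the compounds shown here alone, whether a saturated propyl chain or a chain ending in an amine would behave like allyl or like hexyl remains open.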